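Bromo for methyl on the shared core: expected affinity

The compounds below may be only part of what the source reports. "The series", "measured", "known", "first", "only" and "open" are said of these compounds alone.

Of the compounds shown here, two have numbers so far. Compound 1 `CC(C)CC(=O)c1ccc(OCCCCOc2cccc(F)c2F)c(Br)c1O` gives, in a functional assay for binding affinity to metabotropic glutamate receptor 2 (Homo sapiens), read by GTPgammaS binding (on this read-out higher numbers stand for an effect only at larger amounts of compound and lower numbers for an effect already at smaller amounts), 558 nM. Compound 2 `Cc1c(OCCCCSc2ccncc2)ccc(C(=O)CC(C)C)c1O` gives in this assay 340 nM; this is the lower of the two numbers, and compound 1 sits within the scatter of it, so no order between the two is claimed. Compound 3 `CC(C)CC(=O)c1ccc(OCCCCSc2ccncc2)c(Br)c1O` has not yet been measured. It differs from compound 2 in one place: bromo in place of methyl on an aromatic carbon. Within the data shown here, no measured pair isolates this change, so the size of the step rests on the two numbers only, which show that a bromo-bearing compound and a methyl-bearing compound both fall in the same region. The step from compound 2 to compound 3 is therefore expected to be small, in no clear direction, and not beyond the scatter, as a 1.0-fold higher number from compound 2 to compound 3 (0.01 log units; within the scatter) states. For compound 3 the estimated value in this assay is 350 nM, with a range from 150 nM to 800 nM.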

Compound 3, half-maximal effective concentration: 676 nM
For compound 3 the middle estimate is 1.9-fold (0.29 log units) below the measured one; the range from low to high includes it.
By their numbers in this assay, from the lowest: compounds 2, 1 and 3 (each within the scatter of the next).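

This pair isolates bromo in place of methyl on an aromatic carbon, ortho to a hydroxy group, and in this assay it gives a 2.0-fold higher number from compound 2 to compound 3 (0.30 log units; within the scatter). The exchange therefore does not separate the two compounds at this position, although the step reaches the edge of the scatter. With bromo held in place, the chain end can also change without separating the compounds: (pyridin-4-yl)sulfanyl in place of 2,3-difluorophenoxy gives a 1.2-fold higher number from compound 1 to compound 3 (0.08 log units; within the scatter), and no measurement at hand accounts for either step.

Still open, on these data alone, is whether a chloro, a methoxy or a plain hydrogen at this position would read any differently from bromo and methyl. It is also unknown whether the bromo-for-methyl step would stay this size with 2,3-difluorophenoxy at the chain end, or with a shorter chain.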